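The source may hold more compounds than are shown below. What is called first, only, known or untested is meant among the compounds shown, and "the series" means these compounds.

Measured so far in an assay on membranes from CHO cells for displacement of a labelled ligand from adenosine receptor A1 (Homo sapiens), read by scintillation counting, with a stated time of 60 min, tested at 1 uM; on this read-out higher numbers stand for more inhibition at the one concentration tested (going by the name of the read-out) and lower numbers for less inhibition:
compound 1 `CCCOC(=O)C1=C(C)NC(=O)NC1c1ccoc1`: 50%
compound 2 `CC1=C(C(=O)CC(C)C)C(c2ccoc2)NC(=O)N1`: 23%
compound 3 `CC1=C(C(N)=O)C(c2ccoc2)NC(=O)N1`: 1%

Compound 3 holds the lowest number of the three; the gaps a number 22 percentage points lower from compound 2 to compound 3 (beyond the scatter) and a number 49 percentage points lower from compound 1 to compound 3 (beyond the scatter) are both beyond the scatter. Compound 4 `CC1=C(C(=O)NC(C)C)C(c2ccoc2)NC(=O)N1` follows from compound 3 by isopropyl in place of hydrogen on an amide-type nitrogen. Among the compounds with values here, no measured step touches the amide-type nitrogen; the only steps that bear on it, and loosely, sit on the carbonyl carbon, where propoxy and isobutyl gave higher numbers than amino: a number 27 percentage points lower from compound 1 to compound 2 (beyond the scatter), a number 49 percentage points lower from compound 1 to compound 3 (beyond the scatter), a number 22 percentage points lower from compound 2 to compound 3 (beyond the scatter). On that loose analogy a modest rise in this assay is expected for compound 4, a number 14 percentage points higher from compound 3 to compound 4 (beyond the scatter), with wide uncertainty. Compound 4 is therefore estimated at 15%, range 0% to 35%.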

Compound 4, a percentage reported as inhibition, at one concentration (the size of the read-out at that concentration, not a potency): 1%
For compound 4 the middle estimate is 14 percentage points above the measured one, and the stated range covers the measured number.
By their numbers in this assay, from the lowest: compounds 3 and 4 (each within the scatter of the next); then compound 2; then compound 1.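

In this assay, isopropyl on the amide-type nitrogen leaves the reading unmoved (no change at the digits printed from compound 3 to compound 4 (within the scatter)), so this substitution does not recover what the carbamoyl compound lacks. The isopropylamino group also stays short of both other groups on the carbonyl carbon (a number 22 percentage points lower from compound 2 to compound 4 (beyond the scatter); a number 49 percentage points lower from compound 1 to compound 4 (beyond the scatter)), which extends the gap seen for the amino group to a substituted amide. Nothing at hand explains this result. Still open, as far as these compounds go, is whether a longer chain or a benzyl group on the amide-type nitrogen would shift the reading. Also open, from the compounds shown here alone, is how butoxy on the carbonyl carbon would compare with propoxy.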